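The compounds below may be only part of what the source reports. "The series", "measured", "known", "first", "only" and "open" are said of these compounds alone.

In a functional assay on SK-MEL-2 cells (Homo sapiens) for antiproliferative activity, read by sulforhodamine B assay, with a stated time of 48 h (on this read-out higher numbers stand for weaker inhibition and lower numbers for stronger inhibition), compound 3 (`O=C(Nc1ccc(-n2cc(-c3ccncc3)c(-c3ccc(Cl)c(O)c3)n2)cc1)Nc1ccc(Cl)c(C(F)(F)F)c1`) gives 1700 nM and compound 1 (`COc1cc(-c2nn(-c3ccc(NC(=O)Nc4ccc(Cl)c(C(F)(F)F)c4)cc3)cc2-c2ccncc2)ccc1Cl`) gives 1630 nM as its value, so the two stand level. With hydrogen in place of methyl on an oxygen on an aromatic ring, a 1.0-fold higher number from compound 1 to compound 3 (0.02 log units; within the scatter) is a step within the scatter. Compound 2 (`COc1cc(-c2nn(-c3ccc(NC(=O)c4cc(Cl)cc(Cl)c4)cc3)cc2-c2ccncc2)ccc1Cl`) gives > 100000 nM as a limit of the assay, not a number.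

Compound 4 (`O=C(Nc1ccc(-n2cc(-c3ccncc3)c(-c3ccc(Cl)c(O)c3)n2)cc1)c1ccc(Cl)c(C(F)(F)F)c1`) differs from compound 3 in one place: 4-chloro-3-(trifluoromethyl)phenyl in place of (4-chloro-3-(trifluoromethyl)phenyl)amino on a carbonyl carbon with 4-chloro-3-(trifluoromethyl)phenyl in place of (4-chloro-3-(trifluoromethyl)phenyl)amino on a carbonyl carbon.

Among the measured compounds shown here, the one measured step that removes this amino group is an at least 61-fold higher number from compound 1 to compound 2 (1.78 log units; beyond the scatter) and it is large. It is an imperfect guide, as 3,5-dichlorophenyl enters there, whereas compound 4 keeps the 4-chloro-3-(trifluoromethyl)phenyl group. The direction from compound 2 is therefore carried over, but not its full size. The step to compound 3 suggests that the hydrogen on oxygen should make little difference to this comparison.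

A higher number beyond the scatter is expected, with the estimated step being a 5.9-fold higher number from compound 3 to compound 4 (0.77 log units; beyond the scatter) in this assay on this reasoning. The estimate for compound 4 is 10000 nM with an expected range from 2500 nM to 60000 nM in this read-out.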

Compound 4, half-maximal inhibitory concentration: 1580 nM
For compound 4 the middle estimate is 6.3-fold (0.80 log units) above the measured one; the whole stated range lies above it.
By their numbers in this assay, from the lowest: compounds 4, 1 and 3 (each within the scatter of the next). At a limit, above all of these: compound 2.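

In this assay, replacing (4-chloro-3-(trifluoromethyl)phenyl)amino with 4-chloro-3-(trifluoromethyl)phenyl on the carbonyl carbon is a step within the scatter: a 1.1-fold lower number from compound 3 to compound 4 (0.03 log units; within the scatter). In this pair, then, the read-out does not depend on the amino group or its hydrogen-bond donor, and the large step of an at least 61-fold higher number from compound 1 to compound 2 (1.78 log units; beyond the scatter) cannot be read as the result of losing the amino group alone, since 3,5-dichlorophenyl enters in the same change. Compound 2 gives > 100000 nM, which is a limit of the assay and not a number: the limit of > 100000 nM in this assay, at which 1 of the 4 values shown sits.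

From the compounds shown here alone, it remains open whether the 4-chloro-3-(trifluoromethyl)phenyl group is what keeps compounds 1, 3 and 4 level, or whether an unsubstituted phenyl or a saturated amine such as piperidine on the carbonyl carbon would read the same. Also open, going by these compounds, are how 3,5-dichlorophenyl reads with the hydroxyl form of the core, and whether swapping hydrogen for methyl on the oxygen stays within the scatter when the amino group is absent.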